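The source may hold more compounds than are shown below. What is called first, only, known or untested is meant among the compounds shown, and "the series" means these compounds.

Of the compounds shown here, three built on one shared core have so far been tested in an ADME assay on HEL cells (Homo sapiens) for cytotoxicity; on this read-out higher numbers stand for lower toxicity in this test and lower numbers for higher toxicity in this test. Compound 1 `O=C(COc1cccc2ccccc12)N/N=C/c1ccc(Cl)cc1` gives 100 ug/mL, compound 2 `O=C(COc1cccc2ccccc12)N/N=C/C=C/c1ccccc1` gives 100 ug/mL, and compound 3 `O=C(COc1cccc2ccccc12)N/N=C/c1ccccc1O` gives 20 ug/mL. Compound 3 thus stands at the lowest number of the three, which on this read-out means the highest toxicity among them: the step of a 5.0-fold lower number from compound 1 to compound 3 (0.70 log units; beyond the scatter) and the step of a 5.0-fold lower number from compound 2 to compound 3 (0.70 log units; beyond the scatter) both run downward by the same modest amount, while the step of no change at the digits printed from compound 1 to compound 2 (within the scatter) shows no movement.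

Compound 4 `O=C(COc1cccc2ccccc12)N/N=C/c1cccc(Br)c1` has not yet been measured. It differs from compound 3 in one place: 3-bromophenyl in place of 2-hydroxyphenyl on a carbon with a double bond to nitrogen. Both measured steps into compound 3 bear on this change, since each of them put 2-hydroxyphenyl onto the carbon with a double bond to nitrogen in place of another group and each lowered the number. Compound 4 instead moves away from 2-hydroxyphenyl, and the closest measured comparison is compound 1, whose 4-chlorophenyl gives 100 ug/mL. The expectation is therefore a step back upward of roughly the size seen going into compound 3, giving an expected 5.0-fold higher number from compound 3 to compound 4 (0.70 log units; beyond the scatter). Compound 4 is estimated to give about 100 ug/mL, with a likely range from 40 ug/mL to 100 ug/mL.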

Compound 4, minimum cytotoxic concentration: 100 ug/mL
Beside the measured number, compound 4's estimate shows no gap at the digits printed, within the range that was stated.
By their numbers in this assay, from the lowest: compound 3; then compounds 1, 2 and 4 (each within the scatter of the next).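

In this assay, replacing 2-hydroxyphenyl with 3-bromophenyl on the carbon with a double bond to nitrogen gives a 5.0-fold higher number from compound 3 to compound 4 (0.70 log units; beyond the scatter), the first measured step away from 2-hydroxyphenyl at this position. The other two comparisons, no change at the digits printed from compound 2 to compound 4 (within the scatter) and no change at the digits printed from compound 1 to compound 4 (within the scatter), put 3-bromophenyl level with 2-phenylethenyl and 4-chlorophenyl, so among these four compounds only compound 3 stands apart, and it is also the only one whose group here carries a hydrogen-bond donor. That match is only an observation from four compounds, and no measured evidence is available to explain the difference.

With a single compound standing apart, the compounds shown cannot separate the effect of the hydroxyl group itself from the effect of where it sits, a question that 3-hydroxyphenyl or 4-hydroxyphenyl would address. They also leave open whether 2-methoxyphenyl, 2-aminophenyl or a phenyl ring bearing a carboxylic acid would follow compound 3 or the other three compounds.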